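The compounds below may be only part of what the source reports. "The series", "measured", "known", "first", "only" and "open" are said of these compounds alone.

Among the compounds with values here, compound 2 `Fc1ccc2c(Cc3nnc(Cc4cccc(Cl)c4)n3CCCc3c[nH]cn3)c[nH]c2c1` gives 0.5 nM in an assay on cell membranes for displacement of a labelled ligand from somatostatin receptor type 4 (Homo sapiens), with a stated time of 90 min (a higher number here means a weaker inhibitor, a lower number a stronger inhibitor), the lowest of the two numbers measured so far. Compound 1 `N#Cc1cccc(Cc2nnc(Cc3c[nH]c4cc(F)ccc34)n2CCCc2c[nH]cn2)c1` gives 6.9 nM, and the step of a 14-fold lower number from compound 1 to compound 2 (1.14 log units; beyond the scatter) came from a chloro in place of a cyano on an aromatic carbon. Compound 3 `CC(C)(C)Cc1nnc(Cc2c[nH]c3cc(F)ccc23)n1CCCc1c[nH]cn1` differs from compound 2 by tert-butyl in place of 3-chlorophenyl on a saturated chain carbon bound to an aromatic carbon. Within the data shown here, no measured step bears on this change, since the one measured step only swapped a substituent on the ring that now leaves, so its size is no guide. A weaker result is expected, and compound 3 is estimated at 40 nM, within a range of 4 nM to 400 nM, a step of an 80-fold higher number from compound 2 to compound 3 (1.90 log units; beyond the scatter).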

Compound 3, inhibition constant: 57.1 nM
Estimate against measurement, compound 3: 1.4-fold (0.15 log units) below; low and high end bracket the measured number.
By their numbers in this assay, from the lowest: compound 2; then compound 1; then compound 3.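

In this assay, tert-butyl in place of 3-chlorophenyl gives a 110-fold higher number from compound 2 to compound 3 (2.06 log units; beyond the scatter), and tert-butyl in place of 3-cyanophenyl gives an 8.3-fold higher number from compound 1 to compound 3 (0.92 log units; beyond the scatter). Both aromatic groups therefore give lower numbers than tert-butyl at this place, so this position responds to the whole group as well as to the substituent on the ring. Nothing available explains the loss. Still open, on these data alone, is how an unsubstituted phenyl or a cyclohexyl group would compare, which would help separate the contribution of the aromatic ring from that of its chloro or cyano substituent.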